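A few compounds are considered here, and "the series" means these few. Any claim that something is new, unique, unknown or untested is made for them only; others in the source may bear on it.

Compounds measured so far:
Compound 1 `CNC(=O)/C=C1/COc2cc(OCc3cccc(Cl)c3)ccc21` gives 427 nM in an assay (strain Sprague-Dawley) for inhibition of Amine oxidase [flavin-containing] A (Rattus norvegicus), read by spectrophotometry, with a stated time of 5 min; a lower number here means a stronger inhibitor, a higher number a weaker inhibitor
Compound 2 `CNC(=O)Cc1cc(=O)oc2cc(OS(=O)(=O)c3cccc(Cl)c3)ccc12` gives 111 nM in this assay

Of the compounds shown here, two have been measured, and compound 2 stands with the lowest number of the two. Its nearest neighbour is compound 1, whose number is higher by a margin beyond the usual scatter, so compound 2 is the stronger inhibitor of the pair. The two differ in more than one place, so nothing is said of what drives that gap.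

The step now taken goes from compound 2 to compound 3 `CNCc1cc(=O)oc2cc(OS(=O)(=O)c3cccc(Cl)c3)ccc12`, which has not yet been tested in this assay. The change is methylamino in place of methylcarbamoyl on a saturated chain carbon bound to an aromatic carbon. Among the measured compounds shown here, no step between measured compounds isolates this change, so there is no prior reading of its size or direction. Compound 3 is expected to stay close to compound 2, with the step of a 1.6-fold higher number from compound 2 to compound 3 (0.21 log units; within the scatter) seen as a small one, within or barely beyond the scatter. The estimate for compound 3 in this assay is 180 nM, with a range from 40 nM to 900 nM.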

Compound 3, half-maximal inhibitory concentration: 5300 nM
Estimate against measurement, compound 3: 29-fold (1.47 log units) below; the measured number lies above the stated range.
By their numbers in this assay, from the lowest: compound 2; then compound 1; then compound 3.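

In this assay, among the compounds shown here, methylamino in place of methylcarbamoyl on a saturated chain carbon bound to an aromatic carbon gives a 48-fold higher number from compound 2 to compound 3 (1.68 log units; beyond the scatter) and is the first reading of any change at this place. It shows that this position is far from indifferent to what it carries, and that the methylcarbamoyl form is much the better of the two forms read here. The counts of hydrogen-bond donors and acceptors are the same on both sides, while the group that leaves has 4 heavy atoms and a double bond and the one that enters has 2 heavy atoms and none, and nothing on hand speaks to the reason for the large step.

The step removes the carbonyl and shortens the group at once, so the compounds shown do not tell which of the two goes with the rise in the number. A longer chain carrying the methylamino group would speak to the length alone, and a carboxylic acid or an unsubstituted amide at this place would show how much of the methylcarbamoyl group can vary, but none of these is among the compounds shown.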